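Removing the ethenyl bridge from a hydroxamic acid growth inhibitor

A few compounds are considered here, and "the series" means these few. Any claim that something is new, unique, unknown or untested is made for them only; others in the source may bear on it.

Of the compounds shown here, three sharing one core have been tested in a functional assay on PC-3 cells (Homo sapiens) for inhibition, read by MTT assay, with a stated time of 48 h; on this read-out higher numbers stand for weaker inhibition of growth and lower numbers for stronger inhibition of growth. Compound 1, `C#CCN(C)Cc1cccc(NC(=O)CCCCCCCC(=O)NO)c1`, gives 4070 nM. Compound 2, `C#CCN(C)Cc1cccc(NS(=O)(=O)c2ccc(/C=C/C(=O)NO)cc2)c1`, gives 2230 nM. Compound 3, `C#CCN(C)Cc1cccc(NCc2ccc(/C=C/C(=O)NO)cc2)c1`, gives 850 nM, the lowest of the three numbers, so compound 3 inhibits growth of these cells most strongly; its gaps to compound 2 and to compound 1 both lie beyond the usual scatter of repeated measurements.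

Compound 4, `C#CCN(C)Cc1cccc(NCc2ccc(C(=O)NO)cc2)c1`, has not yet been measured. It differs from compound 3 in one place: hydroxycarbamoyl in place of 2-(hydroxycarbamoyl)ethenyl on an aromatic carbon. For the measured compounds named here, no pair of already measured compounds shows this same change, so there is no direct precedent for its effect. Among hydroxamic acids of this kind, the link between the aromatic ring and the hydroxycarbamoyl group is often important, and the expectation here is a loss of growth inhibition, with a step of a 2.9-fold higher number from compound 3 to compound 4 (0.47 log units; beyond the scatter) that should exceed the scatter. Compound 4 is therefore estimated at 2500 nM in this assay, with a likely range from 800 nM to 8000 nM.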

Compound 4, concentration for 50% growth inhibition: > 10000 nM
Compound 4 was reported as a limit (the forecaster's own chance of this, stated with the estimate: 5%); middle value at least 4.0-fold (0.60 log units) from the limit.
By their numbers in this assay, from the lowest: compound 3; then compounds 2 and 1 (each within the scatter of the next). At a limit, above all of these: compound 4.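

Replacing 2-(hydroxycarbamoyl)ethenyl with hydroxycarbamoyl on the aromatic carbon gives an at least 11-fold higher number from compound 3 to compound 4 (1.07 log units; beyond the scatter) in this assay, a large loss of growth inhibition. Compound 4 gives > 10000 nM, which is a limit of the assay and not a number, and the step rests on it: the limit of > 10000 nM in this assay, at which 1 of the 4 values shown sits.

The earlier compounds shown here offered no pair differing in one place, so they could not isolate this position, whereas this step shows that growth inhibition by compound 3 depends strongly on the group held there.

As far as these compounds go, it remains open whether the double bond itself matters or only the length of the link, which a 2-(hydroxycarbamoyl)ethyl group would help separate. A longer chain carrying the hydroxycarbamoyl group, or a carboxylic acid in its place, would also test how much of this position can change.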